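Adding fluoro to compound 3: an expected flat step

The compounds below may be only part of what the source reports. "The series", "measured", "known", "first", "only" and "open" are said of these compounds alone.

Measured in a functional assay on A549 cells (Homo sapiens) for inhibition, read by MTT assay, with a stated time of 72 h; on this read-out higher numbers stand for weaker inhibition and lower numbers for stronger inhibition:
Compound 1 `O=C1C=CC(O)(c2cc3ccc(F)cc3n2S(=O)(=O)c2ccccc2)C=C1` gives 500 nM
Compound 2 `COC(=O)CCc1ccc(S(=O)(=O)n2c(C3(O)C=CC(=O)C=C3)cc3ccc(F)cc32)cc1` gives 500 nM
Compound 3 `O=C1C=CC(O)(c2cc3ccccc3n2S(=O)(=O)c2ccc(CCC(=O)O)cc2)C=C1` gives 500 nM

Compound 3 stands level with compound 1 and compound 2, so the series shows no spread so far. Compound 4 `O=C1C=CC(O)(c2cc3ccc(F)cc3n2S(=O)(=O)c2ccc(CCC(=O)O)cc2)C=C1` differs from compound 3 by fluoro in place of hydrogen on an aromatic carbon. For the measured compounds named here, no measured step isolates this change. Going by the values given here, the one measured step, no change at the digits printed from compound 1 to compound 2 (within the scatter), concerns a 2-(methoxycarbonyl)ethyl group instead, and it offers no sign of sensitivity in this assay. The closest indirect evidence is that compound 1 carries the fluoro and gives 500 nM, while compound 3 lacks it and gives 500 nM. Those compounds also differ elsewhere, so this comparison is only suggestive. No shift beyond the scatter is therefore expected, and the estimated change is no change at the digits printed from compound 3 to compound 4 (within the scatter). For compound 4 the expected value is 500 nM, with an estimated range from 250 nM to 1000 nM.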

Compound 4, half-maximal inhibitory concentration: 500 nM
The estimate for compound 4 equals the measured number at the digits printed; measured number inside the range.
By their numbers in this assay, from the lowest: compounds 1, 2, 3 and 4 (each within the scatter of the next).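

In this assay, for the compounds shown here, fluoro in place of hydrogen on an aromatic carbon now has a step of its own, no change at the digits printed from compound 3 to compound 4 (within the scatter), where the earlier compounds offered only an indirect comparison. Two further changes read flat in the same way: hydrogen in place of methyl on an oxygen next to a carbonyl group gives no change at the digits printed from compound 2 to compound 4 (within the scatter), and the addition of a 2-carboxyethyl group gives no change at the digits printed from compound 1 to compound 4 (within the scatter). No supporting data are available to explain these flat steps.

With all four compounds level, the set does not show whether this position can move the read-out at all. Going by these compounds, whether chloro, methoxy or an amine in place of the fluoro would shift the value remains open, as does the effect of a longer chain in place of 2-carboxyethyl.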